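The source may hold more compounds than are shown below. What is called first, only, known or untested is meant among the compounds shown, and "the series" means these compounds.

Compound 1 `O=C(/C(=C\c1c(O)cc(O)cc1O)S(=O)(=O)c1ccccc1Br)c1ccc(Br)cc1`: 50000 nM
Compound 2 `Cc1ccc(S(=O)(=O)/C(=C/c2sccc2C)C(=O)c2ccc(Br)cc2)cc1`: 25000 nM

In a functional assay on DU-145 cells (Homo sapiens) for inhibition, read by trypan blue exclusion, with a stated time of 96 h (a higher number here means a weaker inhibitor of growth, a lower number a stronger inhibitor of growth), compound 2 gives 25000 nM, which lies within the usual scatter of compound 1 at 50000 nM, so the two cannot be told apart. Compound 3 `Cc1ccc(S(=O)(=O)/C(=C/c2c(O)cc(O)cc2O)C(=O)c2ccc(Br)cc2)cc1` differs from compound 2 in one place: 2,4,6-trihydroxyphenyl in place of 3-methylthiophen-2-yl on a double-bonded chain carbon bound to a double-bonded chain carbon. Within the data shown here, no measured pair isolates this change. Compound 1 already carries 2,4,6-trihydroxyphenyl and gives 50000 nM, so no step beyond the scatter is expected in this assay. The expected step is a 1.4-fold higher number from compound 2 to compound 3 (0.15 log units; within the scatter). Compound 3 is estimated at 35000 nM, with an expected range of 10000 nM to 100000 nM.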

Compound 3, concentration for 50% growth inhibition: > 100000 nM
Compound 3 was reported as a limit; the forecaster's own chance of this, stated with the estimate: 15%; at least 2.8-fold (0.45 log units) between middle value and limit.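

In this assay compound 3 is reported as a limit, not a number: the limit of > 100000 nM in this assay, at which 1 of the 3 values shown sits. Among these compounds, on this double-bonded chain carbon, 2,4,6-trihydroxyphenyl in place of 3-methylthiophen-2-yl gives an at least 4.0-fold higher number from compound 2 to compound 3 (0.60 log units; beyond the scatter), the first step to clear the scatter, and it means weaker growth inhibition. On the sulfonyl sulfur, 4-methylphenyl in place of 2-bromophenyl gives an at least 2.0-fold higher number from compound 1 to compound 3 (0.30 log units; that floor lies within the scatter), so the size of that change stays unsettled.

The compounds shown do not separate the loss of 3-methylthiophen-2-yl from the arrival of the hydroxyl groups. On these data alone, how an unsubstituted phenyl or a 2,4,6-trimethoxyphenyl would read at this carbon remains open.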